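Adding a third methoxy group to a dimethoxyphenyl arm

This account rests on a few compounds, and the source may have more. Where it says the series, first, only, none or still open, it means among the compounds named here.

Measured compounds:
compound 1 `O=C(Nc1nc2ccc(F)cc2s1)c1cc(-c2ccc(F)cc2)n2nc(-c3ccccc3)cc2n1`: 22900 nM
compound 2 `COc1ccc(-c2cc(C(=O)Nc3nc4ccc(F)cc4s3)nc3cc(-c4ccccc4)nn23)cc1OC`: 22400 nM

Both compounds share one core and differ only in the aromatic ring attached to it. In a functional assay on MCF7 cells (Homo sapiens) for cytotoxicity, read by MTT assay, with a stated time of 48 h (on this read-out higher numbers stand for weaker inhibition and lower numbers for stronger inhibition), compound 1 gives 22900 nM, and compound 2 gives 22400 nM. For the measured compounds named here, the single comparison available, a 1.0-fold lower number from compound 1 to compound 2 (0.01 log units; within the scatter), means compound 2 stands beside compound 1 with no separation that the scatter would not cover.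

Compound 3 `COc1cc(-c2cc(C(=O)Nc3nc4ccc(F)cc4s3)nc3cc(-c4ccccc4)nn23)cc(OC)c1OC` has not been measured. It differs from compound 2 by methoxy in place of hydrogen on an aromatic carbon; read one bond further out, the arm changes from 3,4-dimethoxyphenyl to 3,4,5-trimethoxyphenyl. Going by the values given here, the only step that bears on this change is the one from compound 1 to compound 2, which was flat, so nothing here suggests a shift beyond the scatter in either direction in this assay. Compound 3 is therefore expected to give 22000 nM, between 9000 nM and 55000 nM, a step of a 1.0-fold lower number from compound 2 to compound 3 (0.01 log units; within the scatter).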

Compound 3, half-maximal inhibitory concentration: 27500 nM
Compound 3: middle estimate off by 1.3-fold (0.10 log units), on the low side; the range from low to high includes it.
By their numbers in this assay, from the lowest: compounds 2, 1 and 3 (each within the scatter of the next).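

In this assay putting a methoxy group in place of hydrogen on the 3,4-dimethoxyphenyl arm gives a 1.2-fold higher number from compound 2 to compound 3 (0.09 log units; within the scatter) and so adds a first direct test of this ring carbon, where the change cannot be told apart from repeat measurement. Exchanging the whole arm, 3,4,5-trimethoxyphenyl in place of 4-fluorophenyl, gives a 1.2-fold higher number from compound 1 to compound 3 (0.08 log units; within the scatter) and so extends the flat picture: 4-fluorophenyl, 3,4-dimethoxyphenyl and 3,4,5-trimethoxyphenyl all give readings that this assay does not separate. No supporting data are available to explain this lack of separation.

On these data alone, all three arms are phenyl rings carrying only fluoro or methoxy groups, so the effect of an arm bearing an amine, a carboxylic acid or a longer chain such as butoxy remains open. Also open, as far as these compounds go, is whether any group at this position can move the number beyond the scatter.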